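A Benzyl Cap on the Phenol of Compound 3

The source may hold more compounds than are shown below. What is called first, only, known or untested is meant among the compounds shown, and "the series" means these compounds.

Compound 1, `COC(=O)C1=C(C)NC(=O)NC1c1ccccc1`: "not active" (no number reported)
Compound 2, `COC(=O)C1=C(C)NC(=O)NC1c1ccc(OC)c(OCc2ccccc2)c1`: "not active" (no number reported)
Compound 3, `COC(=O)C1=C(C)NC(=O)NC1c1cccc(O)c1`: 15200 nM

Three compounds share one core and differ only in the groups carried on the phenyl ring. In an assay for inhibition of beta-glucuronidase (Bos taurus), read by spectrophotometry, with a stated time of 30 min (a higher number here means a weaker inhibitor, a lower number a stronger inhibitor), compound 1 gives "not active" (no number reported). Compound 2 gives "not active" (no number reported) in this assay, so no number is available for it either. Among the measured compounds shown here, compound 3, which carries a free hydroxy group, gives 15200 nM in this assay; it holds the only numeric value shown, so it stands as the sole reference point, and no measured step between two numbered compounds exists to compare against.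

Compound 4, `COC(=O)C1=C(C)NC(=O)NC1c1cccc(OCc2ccccc2)c1`, has not yet been measured. It differs from compound 3 by benzyl in place of hydrogen on an oxygen on an aromatic ring. Compound 1, which lacks the hydroxy group, and compound 2, which already carries a benzyloxy group, both returned no number. The expectation is therefore a step toward weaker inhibition, beyond the usual scatter, a 3.0-fold higher number from compound 3 to compound 4 (0.47 log units; beyond the scatter), with a real chance that the assay reports no number at all. Compound 4 is estimated at 45000 nM, in the range 15000 nM to 150000 nM.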

Compound 4, half-maximal inhibitory concentration: "not active" (no number reported)
For compound 4 the study gives words and no number, so the estimate cannot be set against anything.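

In this assay, among the compounds shown here, compound 4 gives "not active" (no number reported) and so, with a number only for compound 3, no step between the two can be read. The compounds shown leave open whether any group other than hydrogen on that oxygen can give a number. No measured evidence bears on this result.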